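The source may report more compounds than this note shows. Statements on the series, on what has been measured and on what is new or still open speak of the compounds shown alone.

Measured so far in an assay on CHO cells for displacement of a labelled ligand from melanin-concentrating hormone receptor 1 (Homo sapiens), read by scintillation counting; a lower number here means a stronger inhibitor, a higher number a weaker inhibitor:

- compound 1 `COC[C@H]1O[C@H](OCc2ccc3ccccc3c2)[C@H](NC(=O)CCCN=C(N)N)[C@@H](OCc2ccc(Cl)cc2)[C@@H]1O`: 920 nM
- compound 2 `COC[C@H]1O[C@H](OCc2ccc(Cl)cc2)[C@H](NC(=O)CCCN=C(N)N)[C@@H](OCc2ccc3ccccc3c2)[C@@H]1O`: 450 nM
- compound 3 `COC[C@H]1O[C@H](OCc2ccc(Cl)cc2)[C@H](NC(=O)CCCN=C(N)N)[C@@H](OCc2ccc(Cl)cc2)[C@@H]1O`: 120 nM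

Compound 3 stands lowest of the three in this assay; compound 2 comes nearest with a higher number, and compound 1 sits furthest away. Both measured steps concern the same kind of position as the change now in question: a 7.7-fold lower number from compound 1 to compound 3 (0.88 log units; beyond the scatter) and a 3.8-fold lower number from compound 2 to compound 3 (0.57 log units; beyond the scatter), each a modest lowering beyond the scatter.

Compound 4 `COC[C@H]1O[C@H](OCCc2ccccc2)[C@H](NC(=O)CCCN=C(N)N)[C@@H](OCc2ccc(Cl)cc2)[C@@H]1O` differs from compound 3 in one place: benzyl in place of 4-chlorophenyl on a saturated chain carbon bound to an oxygen on a saturated carbon. For the measured compounds named here, no measured pair shows this particular swap, so the two known steps only tell that this position is sensitive to what the aryl group is. Removing the chlorine and lengthening the link by one carbon is a different kind of alteration, and the direction cannot be read from the data; a modest worsening seems the more likely outcome, so compound 4 is expected to give 350 nM in this assay, in the range 120 nM to 1100 nM, a step of a 2.9-fold higher number from compound 3 to compound 4 (0.46 log units; beyond the scatter) that is an estimate only.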

Compound 4, half-maximal inhibitory concentration: 540 nM
Estimate against measurement, compound 4: 1.5-fold (0.19 log units) below; the measured number falls inside the stated range.
By their numbers in this assay, from the lowest: compound 3; then compounds 2, 4 and 1 (each within the scatter of the next, the first and the last beyond it).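

In this assay, changing 4-chlorobenzyl to phenethyl at this place gives a 4.5-fold higher number from compound 3 to compound 4 (0.65 log units; beyond the scatter) and so weakens the compound, even though the count of heavy atoms in the group stays the same. Phenethyl also does not separate from the naphthalen-2-yl group at this place, with a 1.7-fold lower number from compound 1 to compound 4 (0.23 log units; within the scatter), so of the three groups seen here only 4-chlorobenzyl stands apart. Nothing measured here explains this difference.

Phenethyl differs from 4-chlorobenzyl both in the chlorine and in the length of the link to the ring, and the compounds shown leave open which of the two matters. On these data alone, a plain benzyl group or a 4-chlorophenethyl group at this place could separate the two, and how an amine in that chain would fare also remains open.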